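This account rests on a few compounds, and the source may have more. Where it says the series, first, only, none or still open, it means among the compounds named here.

Measured in a physicochemical assay for lipophilicity, using the shake flask method, in phosphate buffer, measured as octanol-water partition, with a stated time of 30 min, at pH 7.4; a lower number here means a more polar compound, a higher number a more lipophilic compound
- Compound 1 `O=C1c2ccccc2CN1c1cnc(NCc2c(F)ccc3c2CCO3)n2cnnc12` gives 2.7
- Compound 2 `Fc1ccc2c(c1CNc1ncc(Oc3ccccc3)c3nncn13)CCO2` gives 3.5
- Compound 3 `CN(C(=O)c1ccccc1)c1cnc(NCc2c(F)ccc3c2CCO3)n2cnnc12` gives 2.4

Compound 3 sits within the scatter of compound 1 and clearly under compound 2. Compound 4 `O=C(Nc1cnc(NCc2c(F)ccc3c2CCO3)n2cnnc12)c1ccccc1` differs from compound 3 by one change (hydrogen in place of methyl on an amide-type nitrogen), hydrogen in place of methyl on an amide-type nitrogen. Among the compounds with values here, no measured step makes this exact change. The closest in kind (a number 0.30 log units lower from compound 1 to compound 3 (within the scatter)) stays within the scatter, whereas the large step (a number 1.10 log units lower from compound 2 to compound 3 (beyond the scatter)) exchanges a whole group. Losing one methyl is a smaller edit, so a slight rise that stays within the scatter is expected (a number 0.20 log units higher from compound 3 to compound 4 (within the scatter)). For compound 4 the estimated value is 2.6 with an expected range from 2.1 to 3.1 in this measurement.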

Compound 4, distribution coefficient: 3
Beside the measured number, compound 4's estimate is 0.40 log units below it, within the range that was stated.
By their numbers in this assay, from the lowest: compounds 3, 1 and 4 (each within the scatter of the next, the first and the last beyond it); then compound 2.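

In this assay, taking the methyl off the amide-type nitrogen is enough on its own to move the number beyond the scatter (a number 0.60 log units higher from compound 3 to compound 4 (beyond the scatter)). The benzamido group still does not match phenoxy (a number 0.50 log units lower from compound 2 to compound 4 (beyond the scatter)), while compound 4 stays within the scatter of the group in compound 1 (a number 0.30 log units higher from compound 1 to compound 4 (within the scatter)). Nothing available here explains the effect of the methyl. As far as these compounds go, it remains open how an ethyl group or a longer chain on this nitrogen would compare with methyl and hydrogen.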